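The source may report more compounds than this note shows. Statements on the series, on what has been measured and on what is new or still open speak of the compounds shown alone.

In an assay on isolated protein for inhibition of NADPH oxidase 4 (Homo sapiens), read by chemiluminescence, in the presence of a further agent that is not named here (on this read-out higher numbers stand for weaker inhibition and lower numbers for stronger inhibition), the measured compounds stand as follows: compound 1 `COc1cc(N(C)C)ccc1/C=C1\C(=O)N(c2ccccc2)C(=S)N1C`, 2080 nM; compound 2 `CCN(CC)c1ccc(/C=C2\C(=O)N(c3ccccc3)C(=S)N2C)c(OC)c1`, 1170 nM; compound 3 `CN1C(=S)N(C2CCCCC2)C(=O)/C1=C\c1ccc(N(C)C)cc1O`, 2350 nM.

Compound 1 and compound 2 differ in one place: diethylamino in place of dimethylamino on an aromatic carbon. That change made a 1.8-fold lower number from compound 1 to compound 2 (0.25 log units; within the scatter), so the two numbers lie within the scatter of each other. The values of compound 3 and compound 1 also lie within the scatter of each other, as do those of compound 3 and compound 2; the difference between the core of compound 1 and the core of compound 3 is not broken down here.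

Compound 4 `CCN(CC)c1ccc(/C=C2\C(=O)N(C3CCCCC3)C(=S)N2C)c(O)c1` has not yet been measured. It arises from compound 3 by diethylamino in place of dimethylamino on an aromatic carbon. This is the same kind of change as that from compound 1 to compound 2, though the surroundings differ: in compound 1 the aromatic carbon is meta to a methoxy group, in compound 3 it is meta to a hydroxy group. Compound 4 is therefore expected to show a 1.7-fold lower number from compound 3 to compound 4 (0.22 log units; within the scatter) in this assay, set beside a 1.8-fold lower number from compound 1 to compound 2 (0.25 log units; within the scatter), an expectation resting on that earlier step rather than on any further data. Compound 4 is estimated at 1400 nM, with the range 700 nM to 2800 nM.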

Compound 4, half-maximal inhibitory concentration: 2350 nM
Estimate against measurement, compound 4: 1.7-fold (0.22 log units) below, and the stated range covers the measured number.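

In this assay, diethylamino in place of dimethylamino on an aromatic carbon gave no change at the digits printed from compound 3 to compound 4 (within the scatter). Set beside the earlier step, the change reads alike on the two cores: the same change on two cores in this assay, a 1.8-fold lower number (0.25 log units; within the scatter) from compound 1 to compound 2 and no change at the digits printed (within the scatter) from compound 3 to compound 4, 1.8-fold (0.25 log units) apart, within the scatter of two such steps. This shows that, on these two cores, the change carried across with no gap beyond the scatter, but since neither step itself lies beyond the scatter, it does not show that the change alters inhibition on either core, and two pairs say nothing about how it would behave on any other core.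

The compounds shown leave open what a cyclic amine such as morpholine, or a longer chain such as dipropylamino, would give on that same aromatic carbon. Also open, from the compounds shown here alone, is how a methoxy group and a hydroxy group compare when everything else in the molecule is the same.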